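This account rests on a few compounds, and the source may have more. Where it says the series, first, only, none or still open, it means among the compounds named here.

In an ADME assay on MDCKII-LE cells (Canis lupus familiaris) for permeability (on this read-out lower numbers stand for lower permeability and higher numbers for higher permeability), compound 1 (`Cc1cnc(NC(=O)c2cc(Oc3cnc(C(=O)N(C)C)cn3)c3cc(C)oc3c2)cn1`) gives 22.3 10^-6 cm/s against compound 2 (`CNC(=O)c1cnc(Oc2cc(C(=O)Nc3cnc(C)cn3)cc3oc(C)cc23)cn1`) at 20.9 10^-6 cm/s and compound 3 (`Cc1cnc(NC(=O)c2cc(Oc3cnc(C(=O)N4CCCC4)cn3)c3cc(C)oc3c2)cn1`) at 15.8 10^-6 cm/s and so stands within the scatter of both. Compound 4 (`Cc1ccc(NC(=O)c2cc(Oc3cnc(C(=O)N(C)C)cn3)c3cc(C)oc3c2)nc1`) carries 5-methylpyridin-2-yl in place of 5-methylpyrazin-2-yl on an amide-type nitrogen. The measured steps (a 1.1-fold lower number from compound 1 to compound 2 (0.03 log units; within the scatter); a 1.4-fold lower number from compound 1 to compound 3 (0.15 log units; within the scatter); a 1.3-fold lower number from compound 2 to compound 3 (0.12 log units; within the scatter)) all stay within the scatter, yet none of them alters the 5-methylpyrazin-2-yl group, so they bear on this change only indirectly. No step beyond the scatter is therefore expected in this assay for this change. The estimated step is small (a 1.0-fold higher number from compound 1 to compound 4 (0.01 log units; within the scatter)). Compound 4 is estimated at 23 10^-6 cm/s with an expected range from 12 10^-6 cm/s to 38 10^-6 cm/s in this read-out.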

Compound 4, apparent permeability: 21.5 10^-6 cm/s
Estimate against measurement, compound 4: 1.1-fold (0.03 log units) above; measured number inside the range.
By their numbers in this assay, from the lowest: compounds 3, 2, 4 and 1 (each within the scatter of the next).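

Working at the amide-type nitrogen for the first time, 5-methylpyridin-2-yl in place of 5-methylpyrazin-2-yl gives in this assay a 1.0-fold lower number from compound 1 to compound 4 (0.02 log units; within the scatter). Going from a ring with 2 hetero atoms and 2 hydrogen-bond acceptors to one with 1 of each thus leaves this read-out within the scatter in the setting of compound 1. Nothing at hand explains this result. Still open, as far as these compounds go, is whether a phenyl ring or a saturated amine such as piperidin-1-yl on that nitrogen would hold the read-out, and whether the same exchange behaves alike alongside the pyrrolidin-1-yl carbonyl of compound 3.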